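Cyclopropyl on the amide nitrogen of compound 3

The source may report more compounds than this note shows. Statements on the series, on what has been measured and on what is new or still open speak of the compounds shown alone.

In a functional assay on MCF7 cells (Homo sapiens) for inhibition, read by sulforhodamine B assay, with a stated time of 72 h (on this read-out lower numbers stand for stronger inhibition of growth and higher numbers for weaker inhibition of growth), compound 3 `NC(=O)/C=C/c1ccncc1-c1ccc2ccccc2c1` gives > 10000 nM, which is a limit and not a number. Compound 1 `NNC(=O)CCc1ccncc1-c1ccc2ccccc2c1` gives > 10000 nM, also a limit. Compound 2 `COC1CN(C(=O)/C=C/c2ccncc2-c2ccc3ccccc3c2)C1` gives > 10000 nM, again a limit. Compound 4 `O=C(/C=C/c1ccncc1-c1ccc2ccccc2c1)NC1CC1` differs from compound 3 by cyclopropyl in place of hydrogen on an amide-type nitrogen. Within the data shown here, two measured steps bear on this change: a step that the two limits leave unreadable from compound 2 to compound 3 and a step that the two limits leave unreadable from compound 1 to compound 3. Neither has a readable size, and the evidence amounts to the limit of > 10000 nM in this assay, at which 3 of the 3 values shown sit. No change beyond the scatter and no direction is therefore expected in this assay, and the expected step is a number no higher from compound 3 to compound 4 (the limit leaves the size open). For compound 4 the estimate is 10000 nM, with an expected range from 4000 nM to 25000 nM.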

Compound 4, concentration for 50% growth inhibition: 6840 nM
Estimate against measurement, compound 4: 1.5-fold (0.16 log units) above, within the range that was stated.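

In this assay, compound 4, with cyclopropyl on the amide-type nitrogen, is the only compound shown that gives a number rather than a limit. The steps to it are an at least 1.4-fold lower number from compound 3 to compound 4 (0.16 log units; that floor lies within the scatter), an at least 1.4-fold lower number from compound 2 to compound 4 (0.16 log units; that floor lies within the scatter) and an at least 1.4-fold lower number from compound 1 to compound 4 (0.16 log units; that floor lies within the scatter). The rest of the set stays at the limit: the limit of > 10000 nM in this assay, at which 3 of the 4 values shown sit.

Still open, on these data alone, is whether a larger ring such as cyclohexyl, or an isopropyl or longer alkyl chain on that nitrogen, would move the number beyond the scatter. Also open, as far as these compounds go, is what an amine at the end of such a chain would do.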